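The source may report more compounds than this note shows. Statements on the series, on what has been measured and on what is new or still open speak of the compounds shown alone.

Measured so far in a functional assay on the whole organism (Tail, strain ICR) with Mus musculus as the target, in the tail flick test, with a stated time of 90 min, at a dose of 25 umol/kg by the oral route; on this read-out lower numbers stand for a weaker effect and higher numbers for a stronger effect at the one dose given:
compound 1 `C[C@H](NC(=O)CN(c1nc(Cl)nc2[nH]cnc12)C1CC1)C(=O)OCc1ccccc1` gives 44.2%
compound 2 `CC(C)[C@H](NC(=O)CN(c1nc(Cl)nc2[nH]cnc12)C1CC1)C(=O)OCc1ccccc1` gives 51.3%
compound 3 `O=C(CN(c1nc(Cl)nc2[nH]cnc12)C1CC1)N[C@@H](CC(=O)OCc1ccccc1)C(=O)OCc1ccccc1` gives 15.6%

Compound 3 stands lowest of the three numbers in this assay; its nearest neighbour is compound 1 and its furthest compound 2, both beyond the scatter. The step of a number 7.1 percentage points higher from compound 1 to compound 2 (within the scatter) is within the scatter, so compound 1 and compound 2 are not ordered against each other. The two steps that reach compound 3 are a number 28.6 percentage points lower from compound 1 to compound 3 (beyond the scatter) and a number 35.7 percentage points lower from compound 2 to compound 3 (beyond the scatter): both bring in a benzyloxycarbonyl-bearing side chain and both lower the read-out clearly.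

Compound 4 `NCCCC[C@H](NC(=O)CN(c1nc(Cl)nc2[nH]cnc12)C1CC1)C(=O)OCc1ccccc1` has not yet been measured in this assay. The change from compound 3 is 3-aminopropyl in place of benzyloxycarbonyl on a saturated chain carbon, two bonds along the chain from an amide-type nitrogen and a carbonyl carbon. Among the compounds with values here, the steps that bear on it are the two that introduced the benzyloxycarbonyl group; compound 4 removes that group again and puts a 3-aminopropyl chain in its place. Within the data shown here, no measured pair shows the 3-aminopropyl chain itself, so the size of the reversal is uncertain. On the evidence of the two lowering steps, a rise back toward compound 1 and compound 2 is expected, but not a full return.

Compound 4 is therefore estimated at 35% in this assay, with a range from 15% to 55%. This estimate means a step of a number 19.4 percentage points higher from compound 3 to compound 4 (beyond the scatter).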

Compound 4, a percentage reported as activity, at one dose (the size of the read-out at that dose, not a potency): 35.3%
The estimate for compound 4 lay 0.3 percentage points below the measured number; low and high end bracket the measured number.
By their numbers in this assay, from the lowest: compound 3; then compounds 4, 1 and 2 (each within the scatter of the next, the first and the last beyond it).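

Moving from the benzyloxycarbonyl-bearing side chain to the amine-bearing one gives a number 19.7 percentage points higher from compound 3 to compound 4 (beyond the scatter) in this assay, so the low reading of compound 3 does not extend to every long side chain on this saturated chain carbon, two bonds along the chain from an amide-type nitrogen and a carbonyl carbon. With the methyl compound as reference, the change gives a number 8.9 percentage points lower from compound 1 to compound 4 (within the scatter), so the 4-aminobutyl chain cannot be told apart from methyl at this position in this read-out. With the isopropyl compound as reference, the change gives a number 16 percentage points lower from compound 2 to compound 4 (beyond the scatter), so a clear gap remains there even though compound 1 and compound 2 themselves are not ordered against each other.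

No evidence at hand accounts for any of these steps.

The compounds shown do not separate the contribution of the terminal amine from that of the chain carrying it, since only one amine-bearing chain appears at this position. A plain butyl chain, a shorter or longer aminoalkyl chain, or a carboxylic acid at the end of the side chain would each test a part of that question.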